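A Methyl-Oxadiazole Swap at a Cytotoxicity Ceiling

This account rests on a few compounds, and the source may have more. Where it says the series, first, only, none or still open, it means among the compounds named here.

Compound 1, `CCOC(=O)CCCCCOc1cccc(CN(C(=O)c2ccc(-c3ccc4ccccc4c3)cc2)C(C)C)c1`: > 26000 nM
Compound 2, `CCOC(=O)CCCCCOc1cccc(CN(C(=O)c2ccc(-c3cccc(-c4ccccc4)c3)cc2)C(C)C)c1`: > 26000 nM
Compound 3, `CCOC(=O)CCCCCOc1cccc(CN(C(=O)c2ccc(-c3cccc(C(C)=O)c3)cc2)C(C)C)c1`: > 26000 nM

All three compounds share one core and differ only in the group hanging from its outer aromatic ring. They were tested in an ADME assay on Raji cells (Homo sapiens) for cytotoxicity, read by CellTiter-Glo and resazurin assay, with a stated time of 72 h; on this read-out lower numbers stand for an effect already at smaller amounts and higher numbers for an effect only at larger amounts of compound. Here compound 1 gives no number but only a limit, > 26000 nM. Compound 2 likewise stops at a limit, > 26000 nM. Compound 3 also reaches only a limit, > 26000 nM. So compound 3 stands exactly where the other two stand: at the edge of what this assay can report, with no visible effect on the cells.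

The three single-change steps between them say nothing about size: a step that the two limits leave unreadable from compound 1 to compound 2, a step that the two limits leave unreadable from compound 1 to compound 3 and a step that the two limits leave unreadable from compound 2 to compound 3 are all unreadable because of the limit of > 26000 nM in this assay, at which 3 of the 3 values shown sit.

Compound 4, `CCOC(=O)CCCCCOc1cccc(CN(C(=O)c2ccc(-c3cccc(-c4nnc(C)o4)c3)cc2)C(C)C)c1`, is the next variation on compound 3: 5-methyl-1,3,4-oxadiazol-2-yl in place of acetyl on an aromatic carbon. Among the measured compounds shown here, no measured step bears on this change, and every neighbour of compound 4 sits at the limit. For compound 4 the expected step is therefore a step that the limit leaves unreadable from compound 3 to compound 4, nothing beyond the scatter. Compound 4 is estimated at 30000 nM, within a range from 12000 nM to 100000 nM, and will most probably be reported as a limit again.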

Compound 4, half-maximal effective concentration: > 26000 nM
Compound 4: a limit, no number (the forecaster's own chance of this, stated with the estimate: 85%); the middle value does not contradict the limit.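

The steps joining compound 4 to compound 1, compound 2 and compound 3 cannot be read, because compound 4 also gives only a limit and no number: the limit of > 26000 nM in this assay, at which 4 of the 4 values shown sit.

Going by these compounds, how these four compounds compare with one another in this assay, and whether their different outer groups make any difference there, stays open.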